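This account rests on a few compounds, and the source may have more. Where it says the series, first, only, none or still open, it means among the compounds named here.

Compound 1 `Nc1ncnc2c1ncn2CC#CCCl` gives 90000 nM in a functional assay on L1210 cells (Mus musculus) for inhibition; a lower number here means a stronger inhibitor, a higher number a weaker inhibitor. Compound 3 `Nc1ncnc2c1ncn2CC#CCO` carries hydroxy in place of chloro on a saturated chain carbon bound to a triple-bonded carbon and gives 490000 nM; the change is a step of a 5.4-fold higher number from compound 1 to compound 3 (0.74 log units; beyond the scatter). Compound 2 `Cc1cn(CC#CCCl)c(=O)[nH]c1=O` rests on a different core; how its core differs from that of compound 1 is not broken down here. In this assay compound 2 gives 140000 nM. Compound 4 `Cc1cn(CC#CCO)c(=O)[nH]c1=O` is still to be measured; it differs from compound 2 by hydroxy in place of chloro on a saturated chain carbon bound to a triple-bonded carbon, at the same place as before, so this is the same change made once more. Within the data shown here, from compound 2 to compound 4 a step of about a 5.0-fold higher number from compound 2 to compound 4 (0.70 log units; beyond the scatter) is expected in this assay, because the only earlier example of this change, a 5.4-fold higher number from compound 1 to compound 3 (0.74 log units; beyond the scatter), weakened inhibition by that amount. Compound 4 is therefore estimated at 700000 nM, likely between 280000 nM and 1800000 nM.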

Compound 4, half-maximal inhibitory concentration: > 500000 nM
Compound 4 gave a limit, no number; the forecaster's own chance of this, stated with the estimate: 20%; the middle value lies beyond the limit too.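

In this assay compound 4 gives > 500000 nM, which is a limit of the assay and not a number. Hydroxy in place of chloro weakens inhibition on this second core as well, with an at least 3.5-fold higher number from compound 2 to compound 4 (0.55 log units; beyond the scatter), so the direction of the change carries over from the core of compound 1, where the step is a 5.4-fold higher number from compound 1 to compound 3 (0.74 log units; beyond the scatter). The size of the step on the two cores cannot be compared: the same change on two cores in this assay, a 5.4-fold higher number (0.74 log units; beyond the scatter) from compound 1 to compound 3 and an at least 3.5-fold higher number (0.55 log units; beyond the scatter) from compound 2 to compound 4; the limit leaves it open whether they differ

Going by these compounds, how far compound 4 really lies past its limit stays open, and two cores say little about any others. Also open, on these data alone, is how an amine or a carboxylic acid would behave on a saturated chain carbon bound to a triple-bonded carbon.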